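The source may report more compounds than this note shows. Statements on the series, on what has been measured and on what is new or still open speak of the compounds shown alone.

Compound 1 `COc1ccc(/C=C2\Cc3c(cc(OC)c(OC)c3OC)C2=O)cc1OC`: 9740 nM
Compound 2 `COc1cc(/C=C2\Cc3c(cc(OC)c(OC)c3OC)C2=O)cc(OC)c1OC`: 2790 nM
Compound 3 `COc1ccc(/C=C2\Cc3cc(OC)c(OC)c(OC)c3C2=O)cc1O`: > 10000 nM (a limit, not a number)

All three compounds were tested in a functional assay on A549 cells (Homo sapiens) for antiproliferative activity, read by MTT assay, with a stated time of 48 h; a higher number here means a weaker inhibitor of growth, a lower number a stronger inhibitor of growth. Compound 3 gives no exact number, only > 10000 nM, which is a limit of the assay. Its place on the scale is the limit of > 10000 nM in this assay, at which 1 of the 3 values shown sits.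

Compound 4 `COc1ccc(/C=C2\Cc3cc(OC)c(OC)c(OC)c3C2=O)cc1[N+](=O)[O-]` differs from compound 3 by nitro in place of hydroxy on an aromatic carbon, ortho to a methoxy group (nitro in place of hydroxy on an aromatic carbon). It has yet to be measured in this assay.

Going by the values given here, only one measured step is available as a guide: a 3.5-fold lower number from compound 1 to compound 2 (0.54 log units; beyond the scatter), with methoxy in place of hydrogen on an aromatic carbon. That step involves neither hydroxy nor nitro, so it offers only a rough idea of how far one change of group on an aromatic carbon can move the number. A modest shift towards a lower number is therefore the most that seems reasonable to expect, and no visible change is about as likely. Compound 4 could also turn out to be reported only as a limit.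

The expected change is an at least 1.4-fold lower number from compound 3 to compound 4 (0.15 log units; that floor lies within the scatter). For compound 4 the estimate is 7000 nM, with an expected range of 2500 nM to 20000 nM.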

Compound 4, concentration for 50% growth inhibition: > 10000 nM
Compound 4: only a limit was reported; the forecaster's own chance of this, stated with the estimate: 45%; middle value at least 1.4-fold (0.15 log units) from the limit.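

In this assay, compound 3 and compound 4 are both reported only as limits, not numbers, so the change from hydroxy to nitro gives no readable step: the limit of > 10000 nM in this assay, at which 2 of the 4 values shown sit.

The compounds shown leave open whether compound 3 or compound 4 is the stronger inhibitor of growth, and by how much.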